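Thiophene for pyridine on a hydroxyphenyl pyridine scaffold

A few compounds are considered here, and "the series" means these few. Any claim that something is new, unique, unknown or untested is made for them only; others in the source may bear on it.

Measured compounds:
- compound 2 `Oc1ccc(-c2cc(-c3cccc(Cl)c3)nc(-c3ccccn3)c2)cc1`: 28200 nM
- compound 3 `Oc1cccc(-c2cc(-c3ccc(Cl)cc3)nc(-c3cccnc3)c2)c1`: 16800 nM
- compound 1 `Oc1ccc(-c2cc(-c3ccccn3)nc(-c3ccccc3Cl)c2)cc1`: "not determined" (no result reported)

In a functional assay on HCT-15 cells (Homo sapiens) for cytotoxicity, read by CCK-8 assay and cell counting, with a stated time of 2 days (on this read-out higher numbers stand for weaker inhibition and lower numbers for stronger inhibition), compound 2 gives 28200 nM. In this assay compound 3 gives 16800 nM. Among the compounds with values here, compounds 2 and 3 differ from each other in more than one place, so their two values only show that both sit in the same weak range; no step connects them. Compound 1 gives "not determined" (no result reported) in this assay, and no single step connects it to compound 2 or compound 3, so compound 1 stands nowhere on the numbers shown.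

Compound 4 `Oc1ccc(-c2cc(-c3ccsc3)nc(-c3ccccc3Cl)c2)cc1` is reached from compound 1 by one change: thiophen-3-yl in place of pyridin-2-yl on an aromatic carbon. Within the data shown here, no measured pair carries this change, so its size and direction in this assay are unknown; the expectation is a step no larger than the scatter, in either direction.

Compound 4 is expected to give about 20000 nM in this assay, with a range from 5000 nM to 80000 nM.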

Compound 4, half-maximal inhibitory concentration: 5830 nM
Estimate against measurement, compound 4: 3.4-fold (0.54 log units) above; the measured number falls inside the stated range.
By their numbers in this assay, from the lowest: compound 4; then compounds 3 and 2 (each within the scatter of the next).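

No step can be read from compound 1 to compound 4: compound 1 has no single number, and compound 4 at 5830 nM differs from compound 2 and compound 3 in more than one place. The effect of thiophen-3-yl in place of pyridin-2-yl stays open, and no evidence shown bears on this result.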